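The compounds below may be only part of what the source reports. "The series", "measured", "known", "first", "only" and "open" are said of these compounds alone.

Measured in a functional assay on MCF7 cells (Homo sapiens) for antiproliferative activity, read by MTT assay, with a stated time of 72 h; a lower number here means a stronger inhibitor, a higher number a weaker inhibitor:

- Compound 1 `CCC/C=C/C(=O)Nc1cccc(Oc2nc(Nc3cccc(C#N)c3)nc3c2CSCC3)c1`: 15300 nM
- Compound 2 `C/C=C/C(=O)Nc1cccc(Oc2nc(Nc3ccc(OC)cc3)nc3c2CSCC3)c1`: 24300 nM
- Compound 3 `CC/C=C/C(=O)Nc1cccc(Oc2nc(Nc3ccc(OC)cc3)nc3c2CSCC3)c1`: 31400 nM

Compound 3 lies within the scatter of compound 2, while compound 1 has a lower number than compound 3, by a gap just beyond the scatter. The move to compound 4 `CCC/C=C/C(=O)Nc1cccc(Oc2nc(Nc3ccc(OC)cc3)nc3c2CSCC3)c1` is methyl in place of hydrogen on a saturated chain carbon, two bonds along the chain from a double-bonded chain carbon, which turns but-1-en-1-yl into pent-1-en-1-yl. Going by the values given here, one measured step bears on it, the same kind of addition on a saturated chain carbon bound to a double-bonded chain carbon: a 1.3-fold higher number from compound 2 to compound 3 (0.11 log units; within the scatter). No change beyond the scatter is therefore expected in this assay. The expected step is a 1.1-fold higher number from compound 3 to compound 4 (0.02 log units; within the scatter). For compound 4 the estimated value is 33000 nM, with an expected range from 19000 nM to 56000 nM.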

Compound 4, half-maximal inhibitory concentration: > 50000 nM
Compound 4 ended at the assay's limit; the forecaster's own chance of this, stated with the estimate: 10%; middle value at least 1.5-fold (0.18 log units) from the limit.
By their numbers in this assay, from the lowest: compounds 1, 2 and 3 (each within the scatter of the next, the first and the last beyond it). At a limit, above all of these: compound 4.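

In this assay compound 4 gives a limit and not a number: the limit of > 50000 nM in this assay, at which 1 of the 4 values shown sits. Extending but-1-en-1-yl to pent-1-en-1-yl gives an at least 1.5-fold higher number from compound 3 to compound 4 (0.20 log units; that floor lies within the scatter), while the whole extension gives an at least 2.0-fold higher number from compound 2 to compound 4 (0.31 log units; beyond the scatter), so this chain now shows a separation that the single earlier step did not. With pent-1-en-1-yl in place, the aryl change gives an at least 3.2-fold higher number from compound 1 to compound 4 (0.51 log units; beyond the scatter). Going by these compounds, how far each step extends past its floor stays open. So does what an amine or a hydroxyl group on this saturated chain carbon would do.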